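Chloro to Cyano on the Phenyl of Compound 3

This account rests on a few compounds, and the source may have more. Where it says the series, first, only, none or still open, it means among the compounds named here.

Compound 3 `COc1ccc(-n2nc(Sc3ccc(Cl)cc3)cc(CC[C@@H](C)NC(=O)[C@H]3CCNC[C@@H]3c3ccc(Cl)cc3)c2=O)cc1` gives 58 nM in an assay on CHO cells for binding affinity to Melanocortin receptor 4 (Homo sapiens) (a lower number here means a stronger inhibitor, a higher number a weaker inhibitor), the highest number among the three measured compounds. Compound 1 `COc1ccc(-n2nc(Sc3ccc(Cl)cc3)cc(CC[C@@H](C)NC(=O)[C@H]3CNCC[C@@H]3c3ccccc3F)c2=O)cc1` gives 13 nM in this assay, and compound 2 `COc1ccc(-n2nc(Sc3ccc(Cl)cc3)cc(CC[C@@H](C)NC(=O)[C@H]3CNCC[C@@H]3c3ccc(C)cc3)c2=O)cc1` gives 4.7 nM, so compound 3 stands beyond the scatter from both of them. Among the compounds with values here, the only measured step, a 2.8-fold lower number from compound 1 to compound 2 (0.44 log units; beyond the scatter), concerns a different exchange of the ring on a saturated ring carbon and does not involve compound 3; it shows that the ring on that carbon can move the number, but says nothing about a chloro-to-cyano exchange. Compound 4 `COc1ccc(-n2nc(Sc3ccc(Cl)cc3)cc(CC[C@@H](C)NC(=O)[C@H]3CCNC[C@@H]3c3ccc(C#N)cc3)c2=O)cc1` differs from compound 3 in one place: cyano in place of chloro on an aromatic carbon. Within the data shown here, no measured step in this set bears directly on that exchange. The comparison between compound 1 and compound 2 suggests that a change on that ring shifts the number only modestly, and nothing here points to a direction for compound 4. The step is therefore expected to be small: a 1.0-fold higher number from compound 3 to compound 4 (0.01 log units; within the scatter), quite possibly within the scatter. Compound 4 is estimated at 60 nM, with a range from 20 nM to 180 nM.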

Compound 4, half-maximal inhibitory concentration: 45 nM
For compound 4 the middle estimate is 1.3-fold (0.12 log units) above the measured one; measured number inside the range.
By their numbers in this assay, from the lowest: compound 2; then compound 1; then compounds 4 and 3 (each within the scatter of the next).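

In this assay, within the data shown here, the move from 4-chlorophenyl to 4-cyanophenyl gives the first reading at this position, para to a large group, and the result is small (a 1.3-fold lower number from compound 3 to compound 4 (0.11 log units; within the scatter)). The exchange puts two heavy atoms and a hydrogen-bond acceptor where one chlorine stood, yet the two compounds cannot be told apart, so in this pair the position accepts a nitrile in place of a chlorine without a change beyond the scatter. No measurement here offers an explanation for this result.

This single pair leaves open whether the position would stay as undemanding with other groups, such as an amine, a carboxylic acid or a longer alkyl chain, which could show whether it responds to any exchange at all. It also leaves open whether the same chloro-to-cyano exchange would read alike on the shared core of compound 1 and compound 2, where the amide and the aryl-bearing ring carbon are arranged differently from compound 3.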